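Moving a phenyl around the pyridazine of a sulfone

The source may report more compounds than this note shows. Statements on the series, on what has been measured and on what is new or still open speak of the compounds shown alone.

Compound 1 `CCCCCCCN(CCCCCS(=O)(=O)c1cc(-c2ccccc2)c(-c2ccccc2)nn1)C(=O)Nc1ccc(F)cc1F`: 70%
Compound 2 `CCCCCCCN(CCCCCS(=O)(=O)c1cc(-c2ccccc2)cnn1)C(=O)Nc1ccc(F)cc1F`: 67%
Compound 3 `CCCCCCCN(CCCCCS(=O)(=O)c1ccc(-c2ccccc2)nn1)C(=O)Nc1ccc(F)cc1F`: not yet measured

Of the compounds shown here, two have been measured in an assay on microsomes from liver for inhibition of sterol O-acyltransferase 1 (Rattus norvegicus), tested at 50 ug/mL; a lower number here means less inhibition, a higher number more inhibition at the concentration tested (going by the name of the read-out). Compound 1 gives 70%, and compound 2 gives 67%. Among the measured compounds shown here, the only measured step, a number 3 percentage points lower from compound 1 to compound 2 (within the scatter), comes from a hydrogen in place of phenyl on an aromatic carbon. On these numbers compound 2 stands alongside compound 1: the two values lie within the scatter of each other, so no order between them can be claimed.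

Compound 3 differs from compound 2 in the group on the sulfonyl sulfur: a group of 12 heavy atoms (10 carbon, 2 nitrogen; one six-membered aromatic ring of carbon only, one six-membered aromatic ring with 2 hetero atoms) in place of a group of 12 heavy atoms (10 carbon, 2 nitrogen; one six-membered aromatic ring of carbon only, one six-membered aromatic ring with 2 hetero atoms), on a sulfonyl sulfur. The atoms are the same and only their arrangement changes. For the measured compounds named here, no measured step tests such a rearrangement; the step from compound 1 to compound 2 removed a phenyl rather than moving one, and it stayed within the scatter. There is therefore no ground to expect a step beyond the scatter in this assay .

The expected step is a number 2 percentage points lower from compound 2 to compound 3 (within the scatter). Compound 3 is estimated at 65%, in the range from 45% to 85%.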

Compound 3, a percentage reported as inhibition, at one concentration (the size of the read-out at that concentration, not a potency): 43%
For compound 3 the middle estimate is 22 percentage points above the measured one; measured number below the stated range.
By their numbers in this assay, from the lowest: compound 3; then compounds 2 and 1 (each within the scatter of the next).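

Compound 3 carries the same atoms as compound 2, yet in this assay the rearrangement to 6-phenylpyridazin-3-yl on the sulfonyl sulfur gives a number 24 percentage points lower from compound 2 to compound 3 (beyond the scatter), so in this series the arrangement of the group on that sulfur can matter even when its atom counts stay the same. Removing a phenyl from compound 1 also proves not to be a single change with a single outcome: one removal gives a number 3 percentage points lower from compound 1 to compound 2 (within the scatter), whereas removing the other phenyl gives a number 27 percentage points lower from compound 1 to compound 3 (beyond the scatter). No measurement on hand explains why the two arrangements differ.

The compounds shown leave open whether the remaining phenyl in compound 3 could be replaced by a smaller group such as methyl or chlorine, or by a ring such as pyridyl, with any further effect on the number. They also leave open how the three compounds would compare across a range of concentrations, since each value here comes from a single concentration and is not a measure of potency.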